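Swapping the formyl for a hydroxy on the shared core

The source may report more compounds than this note shows. Statements on the series, on what has been measured and on what is new or still open speak of the compounds shown alone.

Of the compounds shown here, three built on one shared core have been tested in a functional assay (trachea) with Rattus norvegicus as the target; a higher number here means a more potent compound, by a factor of ten per unit of this negative logarithm, a lower number a less potent compound. Compound 1 `CC(=O)c1ccc2c(c1)C(n1ccccc1=O)=CC(C)(C)O2` gives 6.65. Compound 2 `CC1(C)C=C(n2ccccc2=O)c2cc(C(=O)c3ccccc3F)ccc2O1` gives 6.34, and compound 3 `CC1(C)C=C(n2ccccc2=O)c2cc(C=O)ccc2O1` gives 6.14, the lowest of the three. The steps among them all change the group on a carbonyl carbon: a number 0.31 log units lower from compound 1 to compound 2 (beyond the scatter), a number 0.51 log units lower from compound 1 to compound 3 (beyond the scatter), while a number 0.20 log units lower from compound 2 to compound 3 (within the scatter).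

Compound 4 `CC1(C)C=C(n2ccccc2=O)c2cc(O)ccc2O1` takes a different kind of step: the carbonyl itself goes. (hydroxy in place of formyl on an aromatic carbon). For the measured compounds named here, no measured step removes the carbonyl, so the earlier steps bear only loosely on this one. What they do show is that the group on that aromatic carbon matters modestly, with each change so far costing potency or leaving it within the scatter. On that basis a small loss, or no change beyond the scatter, is the expectation here.

Compound 4 is therefore estimated at 5.9 in this assay, within a range from 5.2 to 6.6. The step this implies, a number 0.24 log units lower from compound 3 to compound 4 (within the scatter), is an expectation and not a measurement.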

Compound 4, logarithm of the reciprocal of the active concentration, log(1/C): 5.31
Compound 4: the middle estimate sits 0.59 log units above what was measured; the range from low to high includes it.
By their numbers in this assay, from the lowest: compound 4; then compounds 3 and 2 (each within the scatter of the next); then compound 1.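

In this assay, the earlier changes all kept a carbonyl on this aromatic carbon and altered only what was attached to it, whereas removing the carbonyl gives a number 0.83 log units lower from compound 3 to compound 4 (beyond the scatter), a number 1.03 log units lower from compound 2 to compound 4 (beyond the scatter) and a number 1.34 log units lower from compound 1 to compound 4 (beyond the scatter). The last two of these steps are large, so among these four compounds the number depends more on having a carbonyl group here than on whether hydrogen, methyl or 2-fluorophenyl sits on it. For the compounds shown here, no compound among the four goes against this, but the swap from formyl to hydroxy removes the carbonyl and adds a hydrogen-bond donor in the same step, so the two changes cannot be told apart.

No measurement at hand explains why the number falls. From the compounds shown here alone, it remains open how a methoxy, an amine or a carboxylic acid on this aromatic carbon would compare, and methoxy would be especially informative, since it keeps the oxygen on the ring but has no hydroxy hydrogen.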